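Swapping the Halogenated Phenyl on a Pyrrole Statin Core

The compounds below may be only part of what the source reports. "The series", "measured", "known", "first", "only" and "open" are said of these compounds alone.

Compound 2 `COC(=O)C[C@H](O)C[C@H](O)/C=C/n1c(C(C)C)cc(-c2ccc(F)cc2)c1-c1cccc(Cl)c1` is measured in an assay for inhibition of 3-hydroxy-3-methylglutaryl-coenzyme A reductase (Rattus norvegicus), using microsomes (on this read-out lower numbers stand for stronger inhibition and higher numbers for weaker inhibition), where compound 2 gives 71 nM, the highest of the three numbers recorded. Compound 3 `COC(=O)C[C@H](O)C[C@H](O)/C=C/n1c(C(C)C)cc(-c2ccc(F)cc2)c1-c1cccc(Br)c1` gives 69 nM, and the step of a 1.0-fold lower number from compound 2 to compound 3 (0.01 log units; within the scatter) shows that trading one halogen for another in the same position of that ring changes nothing that can be told from the scatter. Among the compounds with values here, compound 1 `COC(=O)C[C@H](O)C[C@H](O)/C=C/n1c(-c2ccc(F)cc2)c(-c2ccc(F)cc2)c(Br)c1C(C)C` carries two 4-fluorophenyl groups and a bromo on its core and gives 0.3 nM, but it differs from compound 2 in more than one place, so no single step can be drawn from it.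

Compound 4 `COC(=O)C[C@H](O)C[C@H](O)/C=C/n1c(C(C)C)cc(-c2ccc(F)cc2)c1-c1ccc(F)cc1` arises from compound 2 by 4-fluorophenyl in place of 3-chlorophenyl on an aromatic carbon. Within the data shown here, no measured step covers exactly this change; the only single step seen, from chloro to bromo, was flat. Since compound 1, bearing a 4-fluorophenyl in this place, gives 0.3 nM, a lower number than compound 2 is expected for compound 4, and the step of an 8.9-fold lower number from compound 2 to compound 4 (0.95 log units; beyond the scatter) is estimated. Compound 4 is therefore expected to give about 8 nM, between 1.5 nM and 40 nM.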

Compound 4, half-maximal inhibitory concentration: 2 nM
The estimate for compound 4 lay 4.0-fold (0.60 log units) above the measured number; low and high end bracket the measured number.
By their numbers in this assay, from the lowest: compound 1; then compound 4; then compounds 3 and 2 (each within the scatter of the next).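

With the group next to the ring nitrogen, the earlier chloro-to-bromo swap gave no sign of how much this place can matter in this assay: changing to 4-fluorophenyl gives a 36-fold lower number from compound 2 to compound 4 (1.55 log units; beyond the scatter) and, from the 3-bromophenyl, a 35-fold lower number from compound 3 to compound 4 (1.54 log units; beyond the scatter). The bromo on the core of compound 1 also turns out to count on its own, for hydrogen in its place gives a 6.7-fold higher number from compound 1 to compound 4 (0.82 log units; beyond the scatter), so the 4-fluorophenyl alone does not reach the low number of compound 1. Nothing measured here explains why either change has such an effect.

Still open, on these data alone, is whether the large step follows the change of halogen or the change of its place on the phenyl ring. A 4-chlorophenyl or a 3-fluorophenyl group would separate the two, and a plain phenyl would show what the halogen contributes at all.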